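The compounds below may be only part of what the source reports. "The series", "measured", "known", "first", "only" and "open" are said of these compounds alone.

For the measured compounds named here, the compounds measured so far: compound 1 `COc1ccc2ncc(S(=O)(=O)c3ccc(OC)c(Cl)c3)c(N3CCC(C)CC3)c2c1` gives 21%; compound 2 `CC1CCN(c2c(S(=O)(=O)c3cccc(F)c3)cnc3ccc(Cl)cc23)CC1` gives 58%; compound 3 `COc1ccc2ncc(S(=O)(=O)c3ccc(OC)c(OC)c3)c(N3CCC(C)CC3)c2c1` gives -3%, all in an assay on isolated protein for displacement of a labelled ligand from metabotropic glutamate receptor 5 (Homo sapiens), with a stated time of 60 min, tested at 1 uM; on this read-out lower numbers stand for less inhibition and higher numbers for more inhibition at the one concentration tested (going by the name of the read-out).

Compound 3 stands lowest of the three numbers. Going by the values given here, its nearest neighbour on the numbers is compound 1, and the one step that joins them, a number 24 percentage points lower from compound 1 to compound 3 (beyond the scatter), was a modest loss beyond the scatter. Compound 2 stands furthest from compound 3.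

Compound 4 `COc1ccc2ncc(S(=O)(=O)c3cccc(F)c3)c(N3CCC(C)CC3)c2c1` has not been measured. It differs from compound 3 in one place: 3-fluorophenyl in place of 3,4-dimethoxyphenyl on a sulfonyl sulfur. Among the compounds with values here, no measured step covers this exact change. Within the data shown here, the only step that bears on the aromatic ring carried by the sulfonyl sulfur is the one from compound 1 to compound 3, where a methoxy replaced a chloro and the number fell. Compound 2, which also carries a 3-fluorophenyl on its sulfonyl sulfur but differs from compound 4 in its core as well, gives the highest number. Taken together, these point to compound 4 being expected to stand higher than compound 3, by a step of a number 35 percentage points higher from compound 3 to compound 4 (beyond the scatter). Compound 4 is therefore estimated at 32%, within the range 8% to 56%.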

Compound 4, a percentage reported as inhibition, at one concentration (the size of the read-out at that concentration, not a potency): 68%
For compound 4 the middle estimate is 36 percentage points below the measured one, and the stated range ends below it.
By their numbers in this assay, from the lowest: compound 3; then compound 1; then compounds 2 and 4 (each within the scatter of the next).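

Putting 3-fluorophenyl on the sulfonyl sulfur in place of 3,4-dimethoxyphenyl gave a number 71 percentage points higher from compound 3 to compound 4 (beyond the scatter), and putting it in place of 3-chloro-4-methoxyphenyl gave a number 47 percentage points higher from compound 1 to compound 4 (beyond the scatter), so on this core the group at this position can move the number by a large amount. Methoxy in place of chloro on an aromatic carbon, by contrast, gave a number 10 percentage points higher from compound 2 to compound 4 (within the scatter). That change therefore does not read the same in both settings: the same change on two cores in this assay, a number 24 percentage points lower (beyond the scatter) from compound 1 to compound 3 and a number 10 percentage points higher (within the scatter) from compound 2 to compound 4, 34 percentage points apart, beyond the scatter of two such steps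

As far as these compounds go, whether the fluorine itself counts, or only the loss of the methoxy and chloro groups, remains open, and a plain phenyl on the sulfonyl sulfur would separate the two. From the compounds shown here alone, how a nitrile or a carboxylic acid on that ring would read is equally open.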